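Hydroxyphenyl Pyridines Against DU-145 Cells: Positional Isomers

The source may hold more compounds than are shown below. What is called first, only, known or untested is meant among the compounds shown, and "the series" means these compounds.

Compound 1, `Oc1cccc(-c2cc(-c3ccc(C(F)(F)F)cc3)cc(-c3ccccc3O)n2)c1`: > 50000 nM
Compound 2, `Oc1ccc(-c2cc(-c3ccc(C(F)(F)F)cc3)cc(-c3ccccc3O)n2)cc1`: > 50000 nM
Compound 3, `Oc1cccc(-c2cc(-c3cccc(OC(F)(F)F)c3)cc(-c3ccccc3O)n2)c1`: > 50000 nM

Three compounds have been run in a functional assay on DU-145 cells (Homo sapiens) for inhibition; on this read-out higher numbers stand for weaker inhibition and lower numbers for stronger inhibition. For compound 1 the value > 50000 nM is a limit of the assay, not a number. For compound 2 the value > 50000 nM is likewise a limit. For compound 3 the value > 50000 nM is a limit as well, so that all three measured values sit at the limit of > 50000 nM in this assay, at which 3 of the 3 values shown sit. The change 4-hydroxyphenyl in place of 3-hydroxyphenyl on an aromatic carbon therefore gives a step that the two limits leave unreadable from compound 1 to compound 2.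

Compound 4, `Oc1ccc(-c2cc(-c3cccc(OC(F)(F)F)c3)cc(-c3ccccc3O)n2)cc1`, has not yet been measured in this assay. It arises from compound 3 by the change (4-hydroxyphenyl in place of 3-hydroxyphenyl on an aromatic carbon). This is the same kind of change as that from compound 1 to compound 2, though the place differs: in compound 3 the changed carbon is meta to a large group, whereas in compound 1 it is meta to a 4-(trifluoromethyl)phenyl group. How the core of compound 3 differs from that of compound 1 is not broken down here.

Since compound 3 gives only the limit > 50000 nM, and the same kind of change left compound 1 and compound 2 both at the limit, the step that the limit leaves unreadable from compound 3 to compound 4 is expected to be small. Compound 4 is accordingly estimated at 70000 nM, between 25000 nM and 200000 nM, most likely again reported as a limit.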

Compound 4, half-maximal inhibitory concentration: > 50000 nM
Compound 4 gave a limit, no number (the forecaster's own chance of this, stated with the estimate: 85%); the middle value lies beyond the limit too.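

Compound 4 gives > 50000 nM in this assay as a limit, not a number. Compound 3 also has only a limit, so the step between them cannot be read, and neither can the earlier one: the limit of > 50000 nM in this assay, at which 4 of the 4 values shown sit. The compounds shown leave open how strongly any of them inhibits, and whether 3-hydroxyphenyl and 4-hydroxyphenyl differ at all.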